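This account rests on a few compounds, and the source may have more. Where it says the series, first, only, none or still open, it means among the compounds named here.

Measured compounds:
- Compound 1 `COc1ccc(CNCCCNS(=O)(=O)c2cc(C(F)(F)F)cc(C(F)(F)F)c2)cc1OC`: in a functional assay on BXPC-3 cells (Homo sapiens) for inhibition, read by MTT assay, with a stated time of 72 h (a higher number here means a weaker inhibitor of growth, a lower number a stronger inhibitor of growth), compound 1 gives 13000 nM.
- Compound 2 `O=S(=O)(NCCCNCc1ccc(Cl)c(C(F)(F)F)c1)c1cc(C(F)(F)F)cc(C(F)(F)F)c1`: in this assay compound 2 gives 7800 nM.
- Compound 3 `O=S(=O)(NCCCNCc1ccccc1)c1cc(C(F)(F)F)cc(C(F)(F)F)c1`: in this assay compound 3 gives 13000 nM.

Compound 3 sits level with compound 1, the two together the highest numbers of the three; no change at the digits printed from compound 1 to compound 3 (within the scatter) and a 1.7-fold higher number from compound 2 to compound 3 (0.22 log units; within the scatter) both fall within the scatter.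

Compound 4 `O=S(=O)(NCCCNCc1cccc2ccccc12)c1cc(C(F)(F)F)cc(C(F)(F)F)c1` carries naphthalen-1-yl in place of phenyl on a saturated chain carbon bound to an amine nitrogen. The three measured steps all swap the aryl group on that same chain carbon, and none of them, a 1.7-fold lower number from compound 1 to compound 2 (0.22 log units; within the scatter), no change at the digits printed from compound 1 to compound 3 (within the scatter), a 1.7-fold higher number from compound 2 to compound 3 (0.22 log units; within the scatter), moves beyond the scatter. The expectation for this assay is therefore no step beyond the scatter, a 1.2-fold lower number from compound 3 to compound 4 (0.07 log units; within the scatter). Compound 4 is estimated at 11000 nM, range 4000 nM to 30000 nM.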

Compound 4, concentration for 50% growth inhibition: 2700 nM
For compound 4 the middle estimate is 4.1-fold (0.61 log units) above the measured one; the whole stated range lies above it.
By their numbers in this assay, from the lowest: compound 4; then compounds 2, 1 and 3 (each within the scatter of the next).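

Going by these compounds alone, on the saturated chain carbon bound to an amine nitrogen, naphthalen-1-yl is the first aryl change to move beyond the scatter in this assay (a 4.8-fold lower number from compound 3 to compound 4 (0.68 log units; beyond the scatter); a 2.9-fold lower number from compound 2 to compound 4 (0.46 log units; beyond the scatter); a 4.8-fold lower number from compound 1 to compound 4 (0.68 log units; beyond the scatter)). Among compounds 1, 2 and 3, the substituted and unsubstituted phenyl groups stay within the scatter of one another, so among these four compounds only the second aromatic ring goes with a lower number. No supporting measurement accounts for this step.

Open, as far as these compounds go, is whether the attachment point matters, which naphthalen-2-yl would test. Also open, from the compounds shown here alone, are whether a quinolinyl ring, with its ring nitrogen, keeps the lower number and how a longer chain in the linker behaves.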